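Replacing the dihydroxyphenyl arm: notes on compound 4

The source may hold more compounds than are shown below. What is called first, only, known or untested is meant among the compounds shown, and "the series" means these compounds.

Compound 1 `CCOC(=O)C1=C(Nc2ccccc2)S/C(=C\c2ccc(O)c(O)c2)C1=O` heads the three numbers in hand: in a functional assay on MCF7 cells (Homo sapiens) for inhibition, read by MTT assay, with a stated time of 72 h, tested at 10 uM (on this read-out higher numbers stand for more inhibition at the one concentration tested (going by the name of the read-out) and lower numbers for less inhibition), compound 1 gives 38.1%. Compound 3 `CCOC(=O)C1=C(Nc2ccc(C(F)(F)F)cc2)S/C(=C\c2ccc[nH]2)C1=O` comes nearest, with 19.1% in this assay, a gap beyond the scatter, and compound 2 `CCOC(=O)C1=C(Nc2ccccc2)S/C(=C\c2cc(OC)c(O)c(OC)c2)C1=O` lies furthest, with 12.9%, also beyond the scatter. No single-change pairs exist among these three, so no measured step is available.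

Compound 4 `CCOC(=O)C1=C(Nc2ccccc2)S/C(=C\c2cc[nH]c2)C1=O` has not been measured. It differs from compound 1 by 1H-pyrrol-3-yl in place of 3,4-dihydroxyphenyl on a double-bonded chain carbon bound to a double-bonded ring carbon. Compound 1 sits well above compound 3, which also carries a pyrrole arm and gives 19.1%, so a step downward beyond the scatter is expected, roughly a number 18.1 percentage points lower from compound 1 to compound 4 (beyond the scatter). Compound 4 is therefore estimated at 20% in this assay, within a range of 6% to 36%.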

Compound 4, a percentage reported as inhibition, at one concentration (the size of the read-out at that concentration, not a potency): < 10%
Compound 4: a limit, no number (the forecaster's own chance of this, stated with the estimate: 0%); middle value at least 10 percentage points from the limit.
By their numbers in this assay, from the lowest: compounds 2 and 3 (each within the scatter of the next); then compound 1. At a limit, below all of these: compound 4.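

In this assay compound 4 gives < 10%, a limit of the assay and not a number. The series now has its first measured single-change step at this position, on a double-bonded chain carbon bound to a double-bonded ring carbon: 1H-pyrrol-3-yl in place of 3,4-dihydroxyphenyl gives a number at least 28.1 percentage points lower from compound 1 to compound 4 (beyond the scatter). The true size of this step stays bounded on one side only: the limit of < 10% in this assay, at which 1 of the 4 values shown sits.

The compounds shown do not separate the change of ring from the loss of the hydroxyl groups. An unsubstituted phenyl or a 4-hydroxyphenyl arm at this place would bear on that question.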